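The compounds below may be only part of what the source reports. "The series", "measured", "known", "first", "only" and "open" are said of these compounds alone.

Measured so far in a functional assay on A549 cells (Homo sapiens) for inhibition; a lower number here means a stronger inhibitor of growth, a higher number a weaker inhibitor of growth:

Compound 1 `O=S(=O)(Nc1ccccc1)c1ccc(I)cc1`: 23000 nM
Compound 2 `CC(C)(C)c1ccc(S(=O)(=O)Nc2ccccc2O)cc1`: 13000 nM

For the measured compounds named here, these are the only two numbers available, so there is little to compare. Compound 2, at 13000 nM, lies within the usual scatter of compound 1, at 23000 nM, so this assay does not separate them. Going by the values given here, the two differ in more than one place, and no measured pair isolates a single change.

The next compound, compound 3 `Cc1ccccc1NS(=O)(=O)c1ccc(C(C)(C)C)cc1`, keeps the shared core of compound 2 and carries methyl in place of hydroxy on an aromatic carbon, ortho to a large group: methyl in place of hydroxy on an aromatic carbon. Put another way, 2-hydroxyphenyl becomes 2-methylphenyl.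

The data show nothing about this swap directly, so any forecast is cautious. With no evidence for a direction, the expectation is a step that stays within the scatter. The expected change is a 1.2-fold higher number from compound 2 to compound 3 (0.06 log units; within the scatter). In this assay the estimate for compound 3 is 15000 nM, with an expected range of 6000 nM to 40000 nM.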

Compound 3, concentration for 50% growth inhibition: > 80000 nM
Compound 3: only a limit was reported; the forecaster's own chance of this, stated with the estimate: 12%; middle value at least 5.3-fold (0.72 log units) away from the limit.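

For the compounds shown here, this is the first change that can be read at a single place. Putting methyl in place of hydroxy on an aromatic carbon, ortho to a large group, gives an at least 6.1-fold higher number from compound 2 to compound 3 (0.78 log units; beyond the scatter) in this assay. The earlier compounds shown here gave no hint of this, but the pair shows that this position is sensitive: exchanging one heavy atom here, with the shared core unchanged, is enough to produce a weaker inhibitor of growth, and the count of hydrogen-bond donors and acceptors on the group falls to zero in the same step. For compound 3 the reported value is a limit and not a number, so the step has a floor but no known size: the limit of > 80000 nM in this assay, at which 1 of the 3 values shown sits.

From the compounds shown here alone, what stays open is whether the hydroxy is what matters or the methyl is what does harm, since this one swap removes the first and brings in the second. An amine or a methoxy group at the same position, or a plain hydrogen on the same core, would help to pull those two readings apart.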